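A few compounds are considered here, and "the series" means these few. Any claim that something is new, unique, unknown or untested is made for them only; others in the source may bear on it.

Two compounds of this series have numbers in a functional assay on U-87MG ATCC cells for antiproliferative activity against U-87 MG (Homo sapiens), read by MTT assay, with a stated time of 48 h, tested at 100 uM; on this read-out lower numbers stand for a stronger effect and higher numbers for a weaker effect at the one concentration tested. Compound 1 `Cc1nc(-c2ccc(Cl)cc2)sc1C(=O)CSc1nc(-c2ccccc2)c(C#N)c(=O)[nH]1` gives 11.4% in this assay. Compound 2 `COc1ccc(-c2nc(C)c(C(=O)CSc3nc(-c4ccc(OC)cc4)c(C#N)c(=O)[nH]3)s2)cc1` gives 11.5% in this assay. Compound 2 stands at the highest of the two numbers, with compound 1 a fraction of a point lower, a gap within the scatter; no order between the two can be read from these values. Compound 3 `COc1ccc(-c2nc(SCC(=O)c3sc(-c4ccc(Cl)cc4)nc3C)[nH]c(=O)c2C#N)cc1` is not yet measured in this assay. It differs from compound 2 in one place: chloro in place of methoxy on an aromatic carbon. Compound 1 also carries a chloro group and sits at the same level as compound 2, so the change offers no shown reason for a shift. The step of a number 0.5 percentage points higher from compound 2 to compound 3 (within the scatter) is expected to be none beyond the scatter. Compound 3 is therefore estimated at 12% in this assay, with a range from 4% to 25%.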

Compound 3, a percentage reported as activity, at one concentration (the size of the read-out at that concentration, not a potency): 16.6%
The estimate for compound 3 lay 4.6 percentage points below the measured number; the measured number falls inside the stated range.
By their numbers in this assay, from the lowest: compounds 1, 2 and 3 (each within the scatter of the next).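

Within the data shown here, compounds 1 and 2 differ in more than one place, so these are the first single changes that can be read. In this assay chloro in place of methoxy on an aromatic carbon, para to a large group, gives a number 5.1 percentage points higher from compound 2 to compound 3 (within the scatter), so this position takes either group with no step beyond the scatter. Methoxy in place of hydrogen on an aromatic carbon gives a number 5.2 percentage points higher from compound 1 to compound 3 (within the scatter), so that change also stays within the scatter, and no measured property is available to account for either step.

On these data alone, whether an amine or a carboxylic acid on the same aromatic carbon would stay at this level remains open. The compounds shown also leave open whether a longer chain in place of methoxy would give a step beyond the scatter.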